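The compounds below may be only part of what the source reports. "The series", "measured", "known", "first", "only" and "open" are said of these compounds alone.

Measured so far in an assay for inhibition of Fatty-acid amide hydrolase 1 (Rattus norvegicus); on this read-out higher numbers stand for weaker inhibition and lower numbers for stronger inhibition:
Compound 1 `O=C(CCCCCCc1ccccc1Cl)c1ncc(-c2ccccn2)o1` gives 1.9 nM.
Compound 2 `Nc1ccc(CCCCCCC(=O)c2ncc(-c3ccccn3)o2)cc1` gives 3 nM.

Compound 2 carries the higher of the two numbers in this assay, though the step separating it from compound 1 is small: a 1.6-fold higher number from compound 1 to compound 2 (0.20 log units; within the scatter). Compound 3 `O=C(CCCCCS(=O)(=O)c1ccccc1)c1ncc(-c2ccccn2)o1` is not yet measured. It differs from compound 2 thus: phenylsulfonyl in place of 4-aminobenzyl on a saturated chain carbon, five bonds along the chain from a carbonyl carbon. Going by the values given here, the only measured step, the one from compound 1 to compound 2, exchanged one aryl terminus for another on the chain and stayed within the scatter, so the chain terminus tolerated that exchange. Among the compounds with values here, the change to compound 3 goes further: the entering group sits five bonds along the chain from the carbonyl carbon rather than six, and it brings two acceptors and no donor, for which no measured step exists. A modest drift toward a higher number is therefore expected, with wide uncertainty: a 2.0-fold higher number from compound 2 to compound 3 (0.30 log units; within the scatter). Compound 3 is estimated in this assay at 6 nM, range 1.5 nM to 30 nM.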

Compound 3, inhibition constant: 6000 nM
Compound 3: the middle estimate sits 1000-fold (3.00 log units) below what was measured; the whole stated range lies below it.
By their numbers in this assay, from the lowest: compounds 1 and 2 (each within the scatter of the next); then compound 3.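

In this assay, the chain terminus proves far less permissive than the earlier aryl exchange suggested: phenylsulfonyl in place of 4-aminobenzyl gives a 2000-fold higher number from compound 2 to compound 3 (3.30 log units; beyond the scatter), and phenylsulfonyl in place of 2-chlorobenzyl gives a 3200-fold higher number from compound 1 to compound 3 (3.50 log units; beyond the scatter). The entering group keeps a six-membered aromatic ring of carbon only, so that ring at the end of the chain does not by itself preserve the low numbers of the series. No measurement shown here accounts for the loss.

The step changes the sulfonyl link and the place of the aromatic ring along the chain together, and the compounds shown do not separate the two. From the compounds shown here alone, whether a thioether in place of the sulfonyl, or a longer chain carrying the phenylsulfonyl, would restore the low numbers remains open.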